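Three Amide Side Chains, One Level of Antiproliferative Activity

This account rests on a few compounds, and the source may have more. Where it says the series, first, only, none or still open, it means among the compounds named here.

In a functional assay on PC-3 cells (Homo sapiens) for antiproliferative activity, read by MTT assay, with a stated time of 24 h (on this read-out lower numbers stand for stronger inhibition and higher numbers for weaker inhibition), compound 1 `CCn1c(C(=O)NCCN)ccc1C(CC)(CC)c1ccc(OCS(=O)(=O)c2ccccc2)c(C)c1` gives (6890 nM), compound 2 `CCN(CC)CCNC(=O)c1ccc(C(CC)(CC)c2ccc(OCS(=O)(=O)c3ccccc3)c(C)c2)n1CC` gives (7130 nM) and compound 3 `CCn1c(C(=O)N[C@H](CO)C(C)C)ccc1C(CC)(CC)c1ccc(OCS(=O)(=O)c2ccccc2)c(C)c1` gives (7300 nM). Compound 3 therefore stands level with both of the others, and none of these three compounds separates from the rest. Compound 4 `CCn1c(C(=O)N[C@H](CO)CCO)ccc1C(CC)(CC)c1ccc(OCS(=O)(=O)c2ccccc2)c(C)c1` keeps the shared core and differs from compound 3 only in its amide side chain (2-hydroxyethyl in place of isopropyl on a saturated chain carbon bound to an amide-type nitrogen and a saturated chain carbon), with 2-hydroxyethyl in place of isopropyl on a saturated chain carbon bound to an amide-type nitrogen and a saturated chain carbon. Among the compounds with values here, no measured step makes this exact exchange. The closest evidence comes from whole side-chain exchanges on the amide-type nitrogen, which reach compound 3 in two steps (a 1.1-fold higher number from compound 1 to compound 3 (0.03 log units; within the scatter)) and (a 1.0-fold higher number from compound 2 to compound 3 (0.01 log units; within the scatter)), while the change at the end of the chain is similarly small (a 1.0-fold higher number from compound 1 to compound 2 (0.01 log units; within the scatter)). The expected step is therefore (a 1.0-fold higher number from compound 3 to compound 4 (0.01 log units; within the scatter)), with no shift beyond the scatter expected in this assay. Compound 4 is estimated at (7500 nM), with an expected range from 3800 nM to (15000 nM).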

Compound 4, half-maximal inhibitory concentration: 12100 nM
Estimate against measurement, compound 4: 1.6-fold (0.21 log units) below; low and high end bracket the measured number.
By their numbers in this assay, from the lowest: compounds 1, 2, 3 and 4 (each within the scatter of the next).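

In this assay, 2-hydroxyethyl in place of isopropyl on a saturated chain carbon bound to an amide-type nitrogen and a saturated chain carbon gives a small step (a 1.7-fold higher number from compound 3 to compound 4 (0.22 log units; within the scatter)). This is the first change shown at this place on the side chain, and it shows that a group with a hydrogen-bond donor and acceptor can replace one with neither without the number leaving the scatter. The full side chain of compound 4 also remains level with the two amine-bearing side chains (a 1.7-fold higher number from compound 2 to compound 4 (0.23 log units; within the scatter); a 1.8-fold higher number from compound 1 to compound 4 (0.24 log units; within the scatter)), so all four amides stay together.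

Going by these compounds, whether a carboxylic acid, a primary amine or a longer chain such as 3-hydroxypropyl at this place would separate from these four remains open. No measurement here bears on what lies behind these numbers.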